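The source may hold more compounds than are shown below. What is called first, only, known or untested is meant among the compounds shown, and "the series" means these compounds.

Values measured in a physicochemical assay for acid dissociation:

- Compound 1 `CCCCS(=O)(=O)c1ccc(O)c(C(=O)Nc2ccc(C(F)(F)F)cc2)c1`: 6.2
- Compound 2 `CCCCCCCCCCCCS(=O)(=O)c1ccc(O)c(C(=O)Nc2ccc(C(F)(F)F)cc2)c1`: 6.2
- Compound 3 `CCCCCCS(=O)(=O)c1ccc(O)c(C(=O)Nc2ccc(C(F)(F)F)cc2)c1`: 6.2

Compound 3 stands level with the other two compounds at the digits reported. Compound 4 `CS(=O)(=O)c1ccc(O)c(C(=O)Nc2ccc(C(F)(F)F)cc2)c1` differs from it by hydrogen in place of pentyl on a saturated chain carbon bound to a sulfonyl sulfur, which is hydrogen in place of pentyl on a saturated chain carbon bound to a sulfonyl sulfur, or hexyl to methyl when cut one bond further out. Three measured steps alter the same chain: no change at the digits printed from compound 1 to compound 2 (within the scatter), no change at the digits printed from compound 1 to compound 3 (within the scatter) and no change at the digits printed from compound 2 to compound 3 (within the scatter). All three lie within the scatter, although no chain as short as methyl has been measured. No step beyond the scatter is therefore expected in this assay, in either direction. The estimated change is no change at the digits printed from compound 3 to compound 4 (within the scatter). For compound 4 the expected value is 6.2, with an estimated range of 5.9 to 6.5.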

Compound 4, acid dissociation constant: 6.2
Estimate against measurement, compound 4: no gap at the digits printed; the range from low to high includes it.
By their numbers in this assay, from the lowest: compounds 1, 2, 3 and 4 (each within the scatter of the next).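

In this assay, hexyl to methyl on the sulfonyl sulfur gives no change at the digits printed from compound 3 to compound 4 (within the scatter) and the other two chains agree, with no change at the digits printed from compound 2 to compound 4 (within the scatter) and no change at the digits printed from compound 1 to compound 4 (within the scatter) in this assay. The flat result now reaches methyl, the shortest chain shown, so none of the four chains stands apart in this read-out. Nothing available explains this result. The compounds shown leave open whether a chain carrying an amine or a carboxylic acid would stay level with these four. They also leave open what a cyclohexyl or phenyl group on the sulfonyl sulfur would do.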